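A few compounds are considered here, and "the series" means these few. Any claim that something is new, unique, unknown or untested is made for them only; others in the source may bear on it.

Compound 2 `CC1(C)Oc2ccc(C#N)cc2[C@H](Nc2ccccc2)[C@H]1O` gives 1200 nM in a functional assay (aorta) with Rattus norvegicus as the target; on this read-out higher numbers stand for weaker inhibition and lower numbers for stronger inhibition. Compound 3 `CCOC(=O)CCN(c1ccccc1)[C@H]1c2cc(C#N)ccc2OC(C)(C)[C@@H]1O` gives 54000 nM in this assay, the highest of the two numbers shown, and the step of a 45-fold higher number from compound 2 to compound 3 (1.65 log units; beyond the scatter) is large. Compound 1 `CCOC(=O)CN(c1ccccc1)C1c2cc(C#N)ccc2OC(C)(C)C1O` returns only a limit, > 30000 nM, in this assay. The change to compound 4 `CC1(C)Oc2ccc(C#N)cc2[C@H](N(CC#N)c2ccccc2)[C@H]1O` is cyano in place of (ethoxycarbonyl)methyl on a saturated chain carbon bound to a nitrogen on an aromatic ring. Among the measured compounds shown here, the single measured step that bears on it is a 45-fold higher number from compound 2 to compound 3 (1.65 log units; beyond the scatter), which shows how strongly a chain of this kind on the nitrogen raises the number. Compound 1, carrying (ethoxycarbonyl)methyl on that nitrogen, sits at the limit (the limit of > 30000 nM in this assay, at which 1 of the 3 values shown sits). A shorter cyanomethyl chain is expected to recover part of that loss, so the step of a 3.6-fold lower number from compound 3 to compound 4 (0.56 log units; beyond the scatter) is expected to run downward. Compound 4 is therefore estimated at 15000 nM, between 3000 nM and 60000 nM.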

Compound 4, half-maximal inhibitory concentration: 59000 nM
The estimate for compound 4 lay 3.9-fold (0.59 log units) below the measured number, and the stated range covers the measured number.
By their numbers in this assay, from the lowest: compound 2; then compounds 3 and 4 (each within the scatter of the next).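

Replacing (ethoxycarbonyl)methyl with cyano on this saturated chain carbon recovers nothing in this assay, with a 1.1-fold higher number from compound 3 to compound 4 (0.04 log units; within the scatter). The ester is therefore not needed for the high number, since a cyanomethyl group on the nitrogen also gives a large step, a 49-fold higher number from compound 2 to compound 4 (1.69 log units; beyond the scatter). Both compounds with a measured number and a chain on this nitrogen thus sit well above compound 2. From the compounds shown here alone, compound 1 gives only a limit: the limit of > 30000 nM in this assay, at which 1 of the 4 values shown sits. It remains open whether a single methyl on this nitrogen, or an amine or carboxylic acid at the chain end, would stay near compound 2.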